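The source may report more compounds than this note shows. Statements on the series, on what has been measured and on what is new or still open speak of the compounds shown alone.

Compound 1 `COc1ccc(-c2c(C)nc3c(N4CC[C@@H](NC(C)=O)C4)cc(C)nn23)cc1OC` gives in an ADME assay on microsomes from liver (Homo sapiens) for metabolic stability, read by LC-MS, with NADPH named in the record, with a stated time of 60 min, tested at 1 uM, in the absence of a further agent (on this read-out higher numbers stand for a more stable compound and lower numbers for a less stable compound), a value of > 95%, which is a limit of the assay.
Compound 2 `COc1cc(-c2c(C)nc3c(N4CC[C@@H](NC(C)=O)C4)cc(C)nn23)ccc1F` gives in this assay a value of > 95%, again a limit.
Compound 3 `CC(=O)N[C@@H]1CCN(c2cc(C)nn3c(-c4cccs4)c(C)nc23)C1` gives in this assay a value of > 95%, also a limit.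

Compound 1 thus stands at the limit of the assay, where the limit of > 95% in this assay, at which 3 of the 3 values shown sit, places every measured compound, so its standing against compounds 2 and 3 cannot be read. Compound 4 `COc1ccc(-c2c(C)nc3c(N4CC[C@@H](NS(=O)(=O)C(C)C)C4)cc(C)nn23)cc1OC` differs from compound 1 by isopropylsulfonyl in place of acetyl on an amine nitrogen. For the measured compounds named here, no measured step touches this position: the steps a step that the two limits leave unreadable from compound 1 to compound 2, a step that the two limits leave unreadable from compound 1 to compound 3 and a step that the two limits leave unreadable from compound 2 to compound 3 all alter the aromatic group and are unreadable. A step of a number at least 3 percentage points lower from compound 1 to compound 4 (that floor lies within the scatter) is expected, none beyond the scatter, since all three measured compounds sit at the limit (the limit of > 95% in this assay, at which 3 of the 3 values shown sit). Compound 4 is therefore estimated at 92%, within 72% to 100%.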

Compound 4, percent of the compound remaining: > 95%
Compound 4: no number, only a limit (the forecaster's own chance of this, stated with the estimate: 60%); at least 3 percentage points between middle value and limit.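

Compound 4, like compound 1, sits at a limit, so the step between them cannot be read: the limit of > 95% in this assay, at which 4 of the 4 values shown sit.

The compounds shown leave open whether isopropylsulfonyl in place of acetyl changes the read-out in this assay at all, since no compound shown gives a number there.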